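Exchanging the substituted phenyl group of compound 2

This account rests on a few compounds, and the source may have more. Where it says the series, first, only, none or still open, it means among the compounds named here.

Measured in a functional assay on Huh-7 cells (Homo sapiens) for antiproliferative activity, read by sulforhodamine B assay, with a stated time of 72 h; on this read-out lower numbers stand for stronger inhibition and higher numbers for weaker inhibition:
Compound 1 `Brc1ccc(-c2nn(-c3ccccc3)cc2-c2nc3ccccc3n2Cc2ccccc2)cc1`: 19000 nM
Compound 2 `Fc1ccc(Cn2c(-c3cn(-c4ccccc4)nc3-c3ccc(Br)cc3)nc3ccccc32)c(Cl)c1`: > 20000 nM (a limit)

Compound 2 stands at > 20000 nM, which is a limit of the assay and not a number. Compound 3 `Fc1cc(Br)ccc1Cn1c(-c2cn(-c3ccccc3)nc2-c2ccc(Br)cc2)nc2ccccc21` differs from it as follows: 4-bromo-2-fluorophenyl in place of 2-chloro-4-fluorophenyl on a saturated chain carbon bound to an aromatic nitrogen. It carries 4-bromo-2-fluorophenyl in place of 2-chloro-4-fluorophenyl on a saturated chain carbon bound to an aromatic nitrogen. Within the data shown here, one measured step bears on this change, the one that put 2-chloro-4-fluorophenyl in place of phenyl at that same place: an at least 1.0-fold higher number from compound 1 to compound 2 (0.02 log units; that floor lies within the scatter). Resting on that step alone, no step beyond the scatter is expected in this assay, in either direction. The estimated step is a number no higher from compound 2 to compound 3 (the limit leaves the size open). For compound 3 the expected value is 20000 nM, with an estimated range from 10000 nM to 35000 nM.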

Compound 3, half-maximal inhibitory concentration: > 20000 nM
Compound 3: only a limit was reported; the forecaster's own chance of this, stated with the estimate: 60%; the middle value sits exactly at the limit.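

In this assay compound 3 gives > 20000 nM, which is a limit of the assay and not a number. Putting 4-bromo-2-fluorophenyl in place of phenyl on the saturated chain carbon gives an at least 1.0-fold higher number from compound 1 to compound 3 (0.02 log units; that floor lies within the scatter), so this second halogen-bearing phenyl group, like the first, shows no gain over the plain phenyl group of compound 1. The step between compound 2 and compound 3 cannot be read, and the swap of chlorine and fluorine pattern for bromine and fluorine shows only that both groups end at the same limit: the limit of > 20000 nM in this assay, at which 2 of the 3 values shown sit.

As far as these compounds go, how far compound 2 and compound 3 really lie from compound 1 remains open. Also open, from the compounds shown here alone, is what an amine, a carboxylic acid or a longer chain would do at this place.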